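The source may hold more compounds than are shown below. What is called first, only, known or untested is meant among the compounds shown, and "the series" means these compounds.

Measured so far:
Compound 1, `CC(=O)c1c(NCc2ccc(F)cc2F)[nH]c2c(F)cc(F)cc2c1=O`: in an ADME assay on Vero cells (Chlorocebus sabaeus) for cytotoxicity (on this read-out lower numbers stand for higher toxicity in this test and higher numbers for lower toxicity in this test), compound 1 gives > 25000 nM, which is a limit of the assay and not a number.
Compound 2, `CC(=O)c1c(NCc2ccc(F)cc2)[nH]c2c(F)cc(F)cc2c1=O`: in this assay compound 2 gives > 25000 nM, again a limit.
Compound 3, `CC(C)C(=O)c1c(Nc2ccc(F)c(F)c2F)[nH]c2c(F)cc(F)cc2c1=O`: in this assay compound 3 gives > 25000 nM, also a limit.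

Compound 1 and compound 2 differ in one place: hydrogen in place of fluoro on an aromatic carbon. In this assay this change gives a step that the two limits leave unreadable from compound 1 to compound 2. The difference between the cores of compound 1 and compound 3 is not broken down here.

Compound 4, `CC(C)C(=O)c1c(Nc2ccc(F)cc2F)[nH]c2c(F)cc(F)cc2c1=O`, has not yet been measured. It differs from compound 3 by hydrogen in place of fluoro on an aromatic carbon. Among the measured compounds shown here, this is the same kind of change as the one from compound 1 to compound 2, but the surroundings differ: in the earlier pair the changed carbon is ortho to a large group and meta to a fluoro group, whereas here it is ortho to two fluoro groups and meta to a large group. The earlier step cannot be sized because of the limit of > 25000 nM in this assay, at which 3 of the 3 values shown sit.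

Compound 4 is expected at 30000 nM, most likely reported as a limit again. The expected step is a step that the limit leaves unreadable from compound 3 to compound 4, resting on compound 3 giving > 25000 nM and on (the limit of > 25000 nM in this assay, at which 3 of the 3 values shown sit).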

Compound 4, half-maximal cytotoxic concentration: > 25000 nM
Compound 4 ended at the assay's limit (the forecaster's own chance of this, stated with the estimate: 85%); the middle value does not contradict the limit.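

No step can be read between compound 3 and compound 4, since both values are limits of the assay and not numbers, and the same holds for the change from 2,3,4-trifluorophenyl to 2,4-difluorophenyl: the limit of > 25000 nM in this assay, at which 4 of the 4 values shown sit.

The compounds shown leave open how far each one lies beyond that limit in this assay, and so whether removing a fluoro group changes toxicity at all.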